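The source may report more compounds than this note shows. Statements on the series, on what has been measured and on what is new or still open speak of the compounds shown alone.

Of the compounds shown here, three sharing one core have been measured in a functional assay on DU-145 cells (Homo sapiens) for antiproliferative activity, read by propidium iodide staining, with a stated time of 96 h; on this read-out higher numbers stand for weaker inhibition and lower numbers for stronger inhibition. Compound 1 (`CC(O)(COc1ccc(S(F)(F)(F)(F)F)cc1)C(=O)Nc1cccc(S(F)(F)(F)(F)F)c1`) gives 12800 nM, compound 2 (`CC(O)(COc1ccc(C(F)(F)F)cc1)C(=O)Nc1cccc(S(F)(F)(F)(F)F)c1`) gives 13600 nM, and compound 3 (`CC(O)(COc1ccc(OC(F)(F)F)cc1)C(=O)Nc1cccc(S(F)(F)(F)(F)F)c1`) gives 19100 nM. Compound 2 thus stands within the scatter of both other compounds, and the three form a single group on these numbers.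

The next compound to be tested is compound 4 (`CC(O)(COc1ccc(C#N)c(F)c1)C(=O)Nc1cccc(S(F)(F)(F)(F)F)c1`), which has 4-cyano-3-fluorophenyl in place of 4-(trifluoromethyl)phenyl on an oxygen on a saturated carbon.

Within the data shown here, three measured steps bear on this change, each a swap of one group on an aromatic carbon: a 1.1-fold higher number from compound 1 to compound 2 (0.03 log units; within the scatter), a 1.5-fold higher number from compound 1 to compound 3 (0.17 log units; within the scatter) and a 1.4-fold higher number from compound 2 to compound 3 (0.15 log units; within the scatter). All three stay within the scatter. Among the measured compounds shown here, none of them brings in a nitrile, however, so the data hold no direct precedent for the new group, and the range must stay wide. On this evidence, no step beyond the scatter is expected in this assay, and neither direction can be favoured. The estimated change is a 1.0-fold higher number from compound 2 to compound 4 (0.01 log units; within the scatter). The expected value for compound 4 is 14000 nM, with an estimated range from 6000 nM to 33000 nM.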

Compound 4, half-maximal inhibitory concentration: 74800 nM
For compound 4 the middle estimate is 5.3-fold (0.73 log units) below the measured one; measured number outside the range, above it.
By their numbers in this assay, from the lowest: compounds 1, 2 and 3 (each within the scatter of the next); then compound 4.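

In this assay the aryl group on the oxygen on a saturated carbon proved able to move the read-out beyond the scatter, with a 5.5-fold higher number from compound 2 to compound 4 (0.74 log units; beyond the scatter), towards weaker inhibition, whereas the swaps among compounds 1, 2 and 3 had left the numbers within the scatter of each other. So this position is not indifferent to what the ring carries, and tolerance of the earlier fluorinated groups did not extend to 4-cyano-3-fluorophenyl. This single change brings in both a nitrile and a ring fluorine while removing trifluoromethyl, and the step cannot be divided among these parts. Nothing measured here explains it.

The compounds shown leave open whether the nitrile, the fluorine or their combination carries the step, a question that a phenyl bearing only one of the two could address. They also leave open how this position would respond to quite different groups on the ring, such as an amine, a carboxylic acid or a methoxy group, and whether any of these could bring the number below those of the first three compounds.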